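Swapping Chlorine for Bromine: Predicting Compound 4

This account rests on a few compounds, and the source may have more. Where it says the series, first, only, none or still open, it means among the compounds named here.

Of the compounds shown here, three have been measured in an assay on tissue (HeLa cells) for inhibition of Indoleamine 2,3-dioxygenase 1 (Homo sapiens), read by spectrophotometry; on this read-out higher numbers stand for weaker inhibition and lower numbers for stronger inhibition. Compound 1 `O/N=C(/Nc1cccc(Br)c1)c1ccc2occc2c1` gives 1100 nM. Compound 2 `COCc1cc2cc(/C(=N\O)Nc3cccc(Br)c3)ccc2o1` gives 2500 nM, and the step of a 2.3-fold higher number from compound 1 to compound 2 (0.36 log units; beyond the scatter) shows that the methoxymethyl group weakened inhibition modestly. Compound 3 `O/N=C(/Nc1cccc(Cl)c1)c1ccc2oc(-c3ccccc3)cc2c1` gives 10800 nM, the highest of the three numbers and beyond the scatter from both other compounds, so it is the weakest inhibitor seen so far.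

Compound 4 `O/N=C(/Nc1cccc(Br)c1)c1ccc2oc(-c3ccccc3)cc2c1` differs from compound 3 only in bromo in place of chloro on an aromatic carbon. Among the compounds with values here, no measured step involves this kind of halogen exchange; the one step available concerns a methoxymethyl group on a different part of the molecule. With no direct guide, the expected step is a 1.1-fold lower number from compound 3 to compound 4 (0.03 log units; within the scatter), within the scatter. Compound 4 is therefore estimated at 10000 nM, with a range from 4000 nM to 25000 nM.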

Compound 4, half-maximal inhibitory concentration: 8600 nM
Estimate against measurement, compound 4: 1.2-fold (0.07 log units) above, within the range that was stated.
By their numbers in this assay, from the lowest: compound 1; then compound 2; then compounds 4 and 3 (each within the scatter of the next).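

Swapping chloro for bromo on the aromatic carbon gives a 1.3-fold lower number from compound 3 to compound 4 (0.10 log units; within the scatter), so with the phenyl group present this read-out does not tell the two halogens apart. Compound 4 also isolates the phenyl group with bromo held constant: a 7.8-fold higher number from compound 1 to compound 4 (0.89 log units; beyond the scatter) for phenyl in place of hydrogen and a 3.4-fold higher number from compound 2 to compound 4 (0.54 log units; beyond the scatter) for phenyl in place of methoxymethyl, so these two swaps go with weaker inhibition. No evidence here explains these steps.

On these data alone, whether chloro and bromo also match without the phenyl group remains open. So does the effect of an amine or a carboxylic acid at the phenyl position.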